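The compounds below may be only part of what the source reports. "The series", "measured", "known", "first", "only" and "open" are said of these compounds alone.

Compound 1 `CCOC(=O)N1CC[C@H](c2ccc(Cl)cc2)[C@@H]1C(=O)N1CCN(c2ccc(F)cc2[C@@H](N)C(C)C)CC1`: in an assay on HEK293 cells for displacement of a labelled ligand from Melanocortin receptor 4 (Homo sapiens) (on this read-out higher numbers stand for weaker inhibition and lower numbers for stronger inhibition), compound 1 gives 74 nM.
Compound 2 `CCC(=O)N1CC[C@H](c2ccc(Cl)cc2)[C@H]1C(=O)N1CCN(c2ccc(C)cc2[C@@H](N)C(C)C)CC1`: in this assay compound 2 gives 62 nM.
Compound 3 `COc1ccc([C@H]2CCN(C(C)=O)[C@H]2C(=O)N2CCN(c3ccc(C)cc3[C@@H](N)C(C)C)CC2)cc1`: in this assay compound 3 gives 45 nM.

Of the compounds shown here, three share a core and have been measured in this assay. Their numbers lie close together: compound 2, with 62 nM, sits between compound 1 at 74 nM and compound 3 at 45 nM, and each of these gaps falls within the usual scatter of the measurement, so none of the three can be called stronger or weaker than the others on what is shown.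

Compound 4 `Cc1ccc(N2CCN(C(=O)[C@@H]3[C@@H](c4ccc(Cl)cc4)CCN3C(=O)C(C)(C)C)CC2)c([C@@H](N)C(C)C)c1` has not yet been measured in this assay. It differs from compound 2 in one place: tert-butyl in place of ethyl on a carbonyl carbon. Among the compounds with values here, no pair of measured compounds shows this particular change, so its effect cannot be read from the numbers at hand; the only guidance is that three variations around the same core all gave values within the scatter of one another.

On that basis compound 4 is expected to stay close to compound 2, with an estimated step of a 1.1-fold higher number from compound 2 to compound 4 (0.05 log units; within the scatter), that is, none beyond the scatter. The estimate for compound 4 in this assay is 70 nM, with a range from 25 nM to 200 nM.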

Compound 4, inhibition constant: 79 nM
Compound 4: the middle estimate sits 1.1-fold (0.05 log units) below what was measured; the range from low to high includes it.
By their numbers in this assay, from the lowest: compounds 3, 2, 1 and 4 (each within the scatter of the next).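

At the carbonyl carbon whose other neighbour is the amide-type nitrogen in a ring, the exchange of propanoyl for (tert-butyl)carbonyl gives, in this assay, a 1.3-fold higher number from compound 2 to compound 4 (0.11 log units; within the scatter), so on this read-out the two compounds cannot be told apart. Within the data shown here, this is the first direct reading at this position: tert-butyl, with 4 heavy atoms against the 2 of ethyl, still leaves the number within the scatter of the one for the ethyl group, a result the earlier compounds, which differ from one another in more than one place, could not give. Nothing shown explains why this change leaves the number within the scatter.

This single pair, read on the core of compound 2, does not tell whether the same exchange would behave alike on the other compounds of the series. It also leaves open what a longer chain, an amine or a carboxylic acid on the same carbonyl carbon would do in this assay, and whether any of them would give a step beyond the scatter.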